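The compounds below may be only part of what the source reports. "The series", "measured", "known", "first", "only" and "open" are said of these compounds alone.

Measured compounds:
- compound 1, `Cc1c(C(=O)N/N=C\c2ccc(O)cc2)oc2cccc(O)c12`: 21700 nM
- compound 2, `Cc1c(C(=O)N/N=C\c2ccccn2)oc2cccc(O)c12`: >= 40000 nM, a limit of the assay rather than a number
- compound 3, `Cc1c(C(=O)N/N=C\c2c(O)cccc2F)oc2cccc(O)c12`: 8050 nM

The account follows a functional assay on PC-3 cells (Homo sapiens) for inhibition (a lower number here means a stronger inhibitor, a higher number a weaker inhibitor), from compound 2 to compound 4, `Cc1c(C(=O)N/N=C\c2cccc(Br)c2O)oc2cccc(O)c12`. Compound 2 stands at the edge of what the assay reports: its value is a limit, not a number (the limit of >= 40000 nM in this assay, at which 1 of the 3 values shown sits), and it is the only one of the three that sits there. The change is 3-bromo-2-hydroxyphenyl in place of pyridin-2-yl on a carbon with a double bond to nitrogen.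

For the measured compounds named here, two measured steps bear on it. The step of an at least 1.8-fold higher number from compound 1 to compound 2 (0.26 log units; that floor lies within the scatter) places the pyridin-2-yl compound at the limit, whereas the step of an at least 4.9-fold lower number from compound 2 to compound 3 (0.69 log units; beyond the scatter) shows that a hydroxyl-bearing, halogen-bearing phenyl ring in place of pyridin-2-yl gives a clearly lower number. Compound 4 carries a 3-bromo-2-hydroxyphenyl group, which like the ring of compound 3 combines a hydroxyl and a halogen on a carbon-only six-membered aromatic ring. Compound 4 is therefore expected to move in the same direction as compound 3, by a step of roughly an at least 4.0-fold lower number from compound 2 to compound 4 (0.60 log units; beyond the scatter). Compound 4 is estimated to give about 10000 nM, within a range of 4000 nM to 30000 nM.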

Compound 4, half-maximal inhibitory concentration: 16600 nM
The estimate for compound 4 lay 1.7-fold (0.22 log units) below the measured number, within the range that was stated.
By their numbers in this assay, from the lowest: compound 3; then compounds 4 and 1 (each within the scatter of the next). At a limit, above all of these: compound 2.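

Compound 2 remains a limit of the assay and not a number: the limit of >= 40000 nM in this assay, at which 1 of the 4 values shown sits.

In this assay, the step of an at least 2.4-fold lower number from compound 2 to compound 4 (0.38 log units; beyond the scatter) is only a floor, yet it lies beyond the scatter, so 3-bromo-2-hydroxyphenyl joins 2-fluoro-6-hydroxyphenyl as a second ring with a hydroxyl and a halogen that gives a lower number than pyridin-2-yl. The two such rings are not interchangeable at this carbon, as the step of a 2.1-fold higher number from compound 3 to compound 4 (0.31 log units; beyond the scatter) shows, and the step of a 1.3-fold lower number from compound 1 to compound 4 (0.12 log units; within the scatter) leaves 3-bromo-2-hydroxyphenyl no different from the 4-hydroxyphenyl ring, which carries no halogen, so a halogen on the ring does not by itself set the number apart.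

The halogen and the place of the hydroxyl change together between the two halogen-bearing rings, so the compounds shown do not separate the contribution of either one to the gap between them. Going by these compounds, how a plain phenyl ring, or a ring carrying an amine or a carboxylic acid in place of the hydroxyl, would behave at this carbon also stays open.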